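Swapping a Cyclopropyl for a tert-Butylamino Group

The source may report more compounds than this note shows. Statements on the series, on what has been measured and on what is new or still open speak of the compounds shown alone.

Compound 1 `CCN(CC)S(=O)(=O)c1ccc(S(=O)(=O)N2CCC[C@@H](C(=O)NC3CN(C(=O)C4CC4)C3)C2)cc1` was tested in a functional assay on BXPC-3 cells (Homo sapiens) for inhibition, read by MTT assay, with a stated time of 7 days (a higher number here means a weaker inhibitor, a lower number a stronger inhibitor), where compound 1 gives 18500 nM. Among the compounds with a measured number, this is the highest value, meaning compound 1 is the weakest inhibitor of the pair. The nearest neighbour is compound 2 `CCOC(=O)[C@@H]1C[C@H](O)CN(S(=O)(=O)c2ccc(S(=O)(=O)N(CC)CC)cc2)C1`, which in this assay gives 3300 nM, a gap that lies beyond the usual scatter. Compound 3 `CCOC(=O)[C@@H]1CCCN(C(=O)c2ccc(S(=O)(=O)N(CC)CC)cc2)C1` reached only a limit of the assay: in this assay compound 3 gives > 10000 nM. This reflects (the limit of > 10000 nM in this assay, at which 1 of the 3 values shown sits).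

Compound 4 `CCN(CC)S(=O)(=O)c1ccc(S(=O)(=O)N2CCC[C@@H](C(=O)NC3CN(C(=O)NC(C)(C)C)C3)C2)cc1` differs from compound 1 in one place. ((tert-butyl)amino in place of cyclopropyl on a carbonyl carbon). Within the data shown here, no step between two measured compounds here resembles this change, so there is no measured precedent to lean on. The change keeps the carbonyl carbon and the ring it sits on, and alters only the group attached to it. The expected result is a step from compound 1 to compound 4 of a 1.2-fold lower number from compound 1 to compound 4 (0.09 log units; within the scatter), that is, no change beyond the scatter. Compound 4 is therefore estimated to give 15000 nM in this assay, with a plausible range from 5000 nM to 45000 nM.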

Compound 4, half-maximal inhibitory concentration: 10100 nM
Compound 4: middle estimate off by 1.5-fold (0.17 log units), on the high side, within the range that was stated.
By their numbers in this assay, from the lowest: compound 2; then compounds 4 and 1 (each within the scatter of the next).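

Among these compounds, this is the only comparison in the set where two compounds differ in a single place, and in this assay it reads as a 1.8-fold lower number from compound 1 to compound 4 (0.26 log units; within the scatter). On this carbonyl carbon, then, a three-membered carbon ring with no hydrogen-bond donor can give way to an open (tert-butyl)amino group with one hydrogen-bond donor, and neither a gain nor a loss can be told apart from the ordinary spread of repeated measurements. Compound 3 remains a limit and not a number, so it cannot be placed in order against this pair: the limit of > 10000 nM in this assay, at which 1 of the 4 values shown sits.

On these data alone, what a plain dimethylamino group, a carboxylic acid or a longer chain such as n-butyl would do on this same carbonyl carbon stays open, as does whether any replacement here can move the number beyond the scatter. A single pair also cannot tell whether the swap from cyclopropyl to (tert-butyl)amino would behave the same way on a different core or in a different cell line.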